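The source may report more compounds than this note shows. Statements on the series, on what has been measured and on what is new or still open speak of the compounds shown alone.

Measured so far:
- compound 1 `CC/C(=C(/c1ccc(/C=C/C(=O)O)cc1)c1ccc2[nH]ncc2c1)c1ccccc1`: 7.2 nM
- compound 2 `CC/C(=C(/c1ccc(/C=C/C(=O)O)cc1)c1cc(C)c2[nH]ncc2c1)c1ccccc1`: 59 nM
- compound 3 `O=C(O)/C=C/c1ccc(/C(=C(\c2ccccn2)C2CCC2)c2ccc3[nH]nc(F)c3c2)cc1`: 22 nM

In a functional assay on MCF7 cells (Homo sapiens) for cytotoxicity, read by CellTiter-Glo, with a stated time of 5 days (a higher number here means a weaker inhibitor, a lower number a stronger inhibitor), compound 1 gives 7.2 nM. Compound 2 differs from compound 1 by methyl in place of hydrogen on an aromatic carbon, and the step is an 8.2-fold higher number from compound 1 to compound 2 (0.91 log units; beyond the scatter). Compound 3 gives 22 nM; the difference between the cores of compound 3 and compound 1 is not broken down here.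

Compound 4 `Cc1cccnc1/C(=C(\c1ccc(/C=C/C(=O)O)cc1)c1ccc2[nH]nc(F)c2c1)C1CCC1` is not yet measured. It differs from compound 3 by methyl in place of hydrogen on an aromatic carbon. This is the same kind of change as that from compound 1 to compound 2, not the same: in compound 2 the methyl sits on a six-membered aromatic ring of carbon only, part of a fused system of two rings, ortho to a fused ring, meta to a fused ring and meta to a large group; in compound 4 it sits on a six-membered aromatic ring with 1 nitrogen, ortho to a large group, two atoms from the ring nitrogen.

Going by the values given here, the step from compound 3 to compound 4 is expected to be a 2.3-fold higher number from compound 3 to compound 4 (0.36 log units; beyond the scatter), pointing the same way as an 8.2-fold higher number from compound 1 to compound 2 (0.91 log units; beyond the scatter) but smaller, as the surroundings differ and only one precedent exists. Compound 4 is estimated at 50 nM, within 15 nM to 200 nM.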

Compound 4, half-maximal inhibitory concentration: 4.2 nM
Compound 4: middle estimate off by 12-fold (1.08 log units), on the high side; the measured number lies below the stated range.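

In this assay, methyl in place of hydrogen on an aromatic carbon, here pyridin-2-yl to 3-methylpyridin-2-yl, gives a 5.2-fold lower number from compound 3 to compound 4 (0.72 log units; beyond the scatter). This change therefore does not carry over between these two cores, in either direction or size: the same change on two cores in this assay, an 8.2-fold higher number (0.91 log units; beyond the scatter) from compound 1 to compound 2 and a 5.2-fold lower number (0.72 log units; beyond the scatter) from compound 3 to compound 4, 43-fold (1.63 log units) apart, beyond the scatter of two such steps. The two pairs differ both in the ring that takes the methyl and in the rest of the structure, so they do not show which of these differences sets the outcome, and two pairs give no rule for any other core in the series.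

Left open is whether an ethyl group, a methoxy group or a chlorine atom in place of the methyl of 3-methylpyridin-2-yl would move the number the same way as methyl does. Also open, going by these compounds, is what a methyl would do on the core of compound 3 if placed on the ring that carries it in compound 2.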